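The source may report more compounds than this note shows. Statements on the series, on what has been measured and on what is new or still open speak of the compounds shown alone.

Working notes on the series. Compound 1 `COc1nc(-c2ccc(Br)cc2)ccc1[C@@H](c1ccccc1)[C@@](O)(CCN(C)C)c1cccc2ccccc12` is the reference point here, tested in a toxicity assay on Vero cells (Chlorocebus sabaeus) for cytotoxicity; on this read-out higher numbers stand for lower toxicity in this test and lower numbers for higher toxicity in this test. In this assay compound 1 gives > 50 ug/mL, which is a limit of the assay and not a number. For the measured compounds named here, compound 2 `COc1ncc(-c2ccccc2)cc1[C@@H](c1ccccc1)[C@@](O)(CCN(C)C)c1cc(F)cc(F)c1` is the only other compound with a value. In this assay compound 2 gives > 50 ug/mL, again a limit rather than a number. Both values therefore sit at the limit of > 50 ug/mL in this assay, at which 2 of the 2 values shown sit, so compound 1 cannot be placed more finely than at that limit, and of the pair compound 1 and compound 2 nothing more can be said than that both show the same limit. Compound 3 `COc1nc(-c2cccc(F)c2)ccc1[C@@H](c1ccccc1)[C@@](O)(CCN(C)C)c1cccc2ccccc12` has not yet been measured in this assay. It differs from compound 1 in one place: 3-fluorophenyl in place of 4-bromophenyl on an aromatic carbon. The step in this assay is expected to be a step that the limit leaves unreadable from compound 1 to compound 3, none beyond the scatter, given that compound 1 sits at the limit of > 50 ug/mL in this assay, at which 2 of the 2 values shown sit. For compound 3 the estimate in this assay is 60 ug/mL, within the range 30 ug/mL to 120 ug/mL, with a limit once more the most likely outcome.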

Compound 3, half-maximal cytotoxic concentration: > 50 ug/mL
Compound 3: no number, only a limit (the forecaster's own chance of this, stated with the estimate: 80%); the middle value does not contradict the limit.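

In this assay compound 3 gives > 50 ug/mL, a limit of the assay and not a number. Compound 1 also stands at a limit, so no step between compound 1 and compound 3 can be read: the limit of > 50 ug/mL in this assay, at which 3 of the 3 values shown sit.

The compounds shown leave open whether any change to the shared core gives a number rather than a limit in this assay.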